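The source may report more compounds than this note shows. Statements on the series, on what has been measured and on what is new or still open speak of the compounds shown alone.

Measured compounds:
Compound 1 `COc1ccc2c(/C=C/C(=O)c3cc(OC)c(OC)c(SC)c3)c[nH]c2c1` with 115 nM
Compound 2 `COc1ccc2c(/C=C/C(=O)c3cc(OC)c(OC)c(SC)c3)cn(C)c2c1` with 156 nM
Compound 3 `COc1cc(C(=O)/C(C)=C/c2c[nH]c3ccccc23)cc([Se]C)c1OC` with 12 nM

All three were tested in a functional assay on A549 cells (Homo sapiens) for antiproliferative activity, read by MTT assay, with a stated time of 48 h; a higher number here means a weaker inhibitor, a lower number a stronger inhibitor. Compound 2 differs from compound 1 only by methyl in place of hydrogen on an aromatic nitrogen. This change produced a 1.4-fold higher number from compound 1 to compound 2 (0.13 log units; within the scatter), so the two are indistinguishable here. Compound 3 carries a different core; the difference between the core of compound 1 and that of compound 3 is not broken down here. It is the most potent of the measured set, its value in this assay lying well beyond the scatter from both compound 1 and compound 2.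

Compound 4 `COc1cc(C(=O)/C(C)=C/c2cn(C)c3ccccc23)cc([Se]C)c1OC` has not yet been measured. It differs from compound 3 by methyl in place of hydrogen on an aromatic nitrogen, the same change that separates compound 1 from compound 2, at the same kind of place. Within the data shown here, since that earlier change gave a 1.4-fold higher number from compound 1 to compound 2 (0.13 log units; within the scatter), the step from compound 3 to compound 4 is expected to be of similar size, a 1.3-fold higher number from compound 3 to compound 4 (0.12 log units; within the scatter), because the one precedent, a 1.4-fold higher number from compound 1 to compound 2 (0.13 log units; within the scatter), stayed within the scatter. On that basis compound 4 is expected to give about 16 nM in this assay, most likely between 7 nM and 40 nM.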

Compound 4, half-maximal inhibitory concentration: 18 nM
The estimate for compound 4 lay 1.1-fold (0.05 log units) below the measured number; measured number inside the range.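

In this assay methyl in place of hydrogen on an aromatic nitrogen gave a 1.5-fold higher number from compound 3 to compound 4 (0.18 log units; within the scatter) and so leaves the two compounds indistinguishable. The change therefore carried from one core to the other without a detectable difference in its size: the same change on two cores in this assay, a 1.4-fold higher number (0.13 log units; within the scatter) from compound 1 to compound 2 and a 1.5-fold higher number (0.18 log units; within the scatter) from compound 3 to compound 4, 1.1-fold (0.04 log units) apart, within the scatter of two such steps. Among these compounds, this shows only that the step stayed small on these two cores in this one assay; it does not show that the same would hold on any other core, and effects smaller than the scatter cannot be seen in either pair.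

The compounds shown leave open what happens when that nitrogen carries something other than hydrogen or methyl, such as an ethyl group, a benzyl group or a longer chain ending in an amine. They also leave open whether the step stays this small in any other cell line.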